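Aromatic ether in place of cyclohexylamine at the amide chain

The source may report more compounds than this note shows. Statements on the series, on what has been measured and on what is new or still open speak of the compounds shown alone.

Three analogues of the shared core of compound 1 `CC(C)C[C@H](N)c1cc(C(F)(F)F)ccc1N1CCN(C(=O)CCC(N)=O)CC1` have been measured in an assay on HEK293 cells for displacement of a labelled ligand from Melanocortin receptor 4 (Homo sapiens) (on this read-out lower numbers stand for stronger inhibition and higher numbers for weaker inhibition), and a fourth waits. Compound 1 returns only a limit, > 10000 nM, in this assay. Compound 2 `CC(C)C[C@H](N)c1cc(C(F)(F)F)ccc1N1CCN(C(=O)C(C)Cc2ccc(Cl)cc2)CC1` gives 47 nM in this assay, and compound 3 `CC(C)C[C@H](N)c1cc(C(F)(F)F)ccc1N1CCN(C(=O)CCNC2CCCCC2)CC1` gives 4800 nM. Among the two plain numbers compound 3 stands highest, with compound 2 nearest to it: a 100-fold higher number from compound 2 to compound 3 (2.01 log units; beyond the scatter). The other measured steps point the same way: an at least 210-fold lower number from compound 1 to compound 2 (2.32 log units; beyond the scatter), a large gain once the chain carries a chlorinated aromatic ring, while an at least 2.0-fold lower number from compound 1 to compound 3 (0.31 log units; beyond the scatter) shows a far smaller gain for the cyclohexylamino chain.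

Compound 4 `Cc1ccc(OCC(=O)N2CCN(c3ccc(C(F)(F)F)cc3[C@@H](N)CC(C)C)CC2)c(C)c1` returns to an aromatic ring at the end of the amide chain. The change is 2,4-dimethylphenoxy in place of (cyclohexylamino)methyl on a saturated chain carbon bound to a carbonyl carbon. The step that bears most on it runs in the opposite direction: a 100-fold higher number from compound 2 to compound 3 (2.01 log units; beyond the scatter), where the loss of the 4-chlorobenzyl-bearing chain cost dearly in this assay. Reversing that kind of change, compound 4 is expected to show a large fall in this assay, a 32-fold lower number from compound 3 to compound 4 (1.51 log units; beyond the scatter), though an ether link and different substitution leave the extent uncertain. Compound 4 is therefore estimated at 150 nM in this assay, within a range from 30 nM to 1000 nM.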

Compound 4, inhibition constant: 4000 nM
For compound 4 the middle estimate is 27-fold (1.43 log units) below the measured one, outside the stated range (above it).
By their numbers in this assay, from the lowest: compound 2; then compounds 4 and 3 (each within the scatter of the next). At a limit, above all of these: compound 1.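

Setting 2,4-dimethylphenoxy in place of (cyclohexylamino)methyl on this saturated chain carbon leaves the binding result in this assay unresolved from that of the amine, a 1.2-fold lower number from compound 3 to compound 4 (0.08 log units; within the scatter), so at this position an aromatic ring in place of the cyclohexylamine makes no visible difference. An aromatic ring at the end of the amide chain is thus no general route to the strong binding of compound 2, which goes against any such reading, as an 85-fold higher number from compound 2 to compound 4 (1.93 log units; beyond the scatter) shows, and compounds 3 and 4 both stay far from it. The remaining step, an at least 2.5-fold lower number from compound 1 to compound 4 (0.39 log units; beyond the scatter), is only a bound and rests on a limit of the assay: the limit of > 10000 nM in this assay, at which 1 of the 4 values shown sits.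

The compounds shown leave open which feature of compound 2 carries its advantage over compound 4: the chlorine, the methyl branch on the chain, or the carbon chain in place of the ether link. A 4-chlorophenoxy group on the same chain, or a 2,4-dimethylbenzyl group in place of the 2,4-dimethylphenoxy, would begin to separate these.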